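A Cyclohexyl for Benzyl Swap on an Amide-type Nitrogen

The source may hold more compounds than are shown below. What is called first, only, known or untested is meant among the compounds shown, and "the series" means these compounds.

Measured so far:
compound 1 `CCNC(=O)NS(=O)(=O)c1ccc(-n2nc(C)cc2C)cc1`: in a functional assay on the whole organism (blood, strain albino) with Mus musculus as the target, with stated times of 6 days and 4 h, at a dose of 0.4 mmol/kg by the oral route (a lower number here means less inhibition, a higher number more inhibition at the dose given (going by the name of the read-out)), compound 1 gives < 1%, a limit of the assay.
compound 2 `Cc1cc(C(=O)O)nn1-c1ccc(S(=O)(=O)NC(=O)NCc2ccccc2)cc1`: compound 2 gives 0%.
compound 3 `Cc1cc(C)n(-c2ccc(S(=O)(=O)NC(=S)NCc3ccccc3)cc2)n1`: compound 3 gives 0%.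

Compound 2 stands level with compound 3 at the digits given, within the scatter. For compound 1 only a limit is known (the limit of < 1% in this assay, at which 1 of the 3 values shown sits). Compound 4 `Cc1cc(C(=O)O)nn1-c1ccc(S(=O)(=O)NC(=O)NC2CCCCC2)cc1` differs from compound 2 in one place: cyclohexyl in place of benzyl on an amide-type nitrogen. For the measured compounds named here, no step between measured compounds is known, so the size of this change in this assay cannot be read from any measured pair. With compound 2 at 0% and compound 3 at 0%, no step beyond the scatter is expected. Compound 4 is therefore expected to give 1%, in the range 0% to 10%. The expected step is a number 1 percentage points higher from compound 2 to compound 4 (within the scatter).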

Compound 4, a percentage reported as inhibition, in the whole organism at one dose (the size of the read-out at that dose, not a potency): 1%
Estimate against measurement, compound 4: no gap at the digits printed, and the stated range covers the measured number.
By their numbers in this assay, from the lowest: compounds 2, 3 and 4 (each within the scatter of the next).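

In this assay, for the compounds shown here, putting cyclohexyl in place of benzyl on the amide-type nitrogen gives the first step that can be read at this position: a number 1 percentage points higher from compound 2 to compound 4 (within the scatter). In this pair, a non-aromatic ring of carbon and an aromatic one on this nitrogen cannot be told apart at the single dose given. One limit bears on this low range of the read-out: the limit of < 1% in this assay, at which 1 of the 4 values shown sits.

From the compounds shown here alone, whether a longer chain or an amine on this nitrogen would move the read-out beyond the scatter remains open. So does whether the same change would read alike on another core.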